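Working notes on the series: compound 3 to compound 4

The source may hold more compounds than are shown below. What is called first, only, known or untested is meant among the compounds shown, and "the series" means these compounds.

Compound 3 `CN(C)CCn1cnnc1-c1cc(Oc2ccc(NC(=O)N/N=C/c3c[nH]c4ccccc34)cc2F)ccn1` gives 3620 nM in an ADME assay on WI-38 cells (Homo sapiens) for cytotoxicity, read by MTT assay, with a stated time of 72 h; on this read-out lower numbers stand for stronger inhibition and higher numbers for weaker inhibition. Of the two numbers available it stands highest; the nearest is compound 1 `CN(C)CCn1cnnc1-c1cc(Oc2ccc(NC(=O)N/N=C/c3ccc(F)cc3Cl)cc2F)ccn1`, which in this assay gives 2090 nM, and the step of a 1.7-fold higher number from compound 1 to compound 3 (0.24 log units; within the scatter) lies within the scatter. Compound 2 `CN(C)CCn1cnnc1-c1cc(Oc2ccc(NC(=O)N/N=C/c3ccc(O)cc3)cc2F)ccn1` has no result in this assay: "not determined" (no result reported).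

Compound 4 `CN(C)CCn1cnnc1-c1cc(Oc2ccc(NC(=O)N/N=C/c3ccc(F)cc3F)cc2F)ccn1` differs from compound 3 in one place: 2,4-difluorophenyl in place of 1H-indol-3-yl on a carbon with a double bond to nitrogen. Going by the values given here, the only measured step that bears on this change is the one from compound 1 to compound 3, in which 2-chloro-4-fluorophenyl gave way to 1H-indol-3-yl on a carbon with a double bond to nitrogen and the number moved a 1.7-fold higher number from compound 1 to compound 3 (0.24 log units; within the scatter), within the scatter. Compound 4 brings a fluorinated phenyl back onto that carbon, so no step beyond the scatter is expected, with a slight drift toward a lower number because a 1.7-fold higher number from compound 1 to compound 3 (0.24 log units; within the scatter) ran the other way. Compound 4 is therefore estimated at 2400 nM, within 1100 nM to 5200 nM. For compound 4 this amounts to an expected step of a 1.5-fold lower number from compound 3 to compound 4 (0.18 log units; within the scatter).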

Compound 4, half-maximal inhibitory concentration: 5030 nM
Beside the measured number, compound 4's estimate is 2.1-fold (0.32 log units) below it; measured number inside the range.
By their numbers in this assay, from the lowest: compounds 1, 3 and 4 (each within the scatter of the next, the first and the last beyond it).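

Read in this assay, 2,4-difluorophenyl in place of 1H-indol-3-yl on a carbon with a double bond to nitrogen gives a 1.4-fold higher number from compound 3 to compound 4 (0.14 log units; within the scatter), so a group with no hydrogen-bond donor and only one ring can stand at this place without a step beyond the scatter. Fluoro in place of chloro on an aromatic carbon gives a 2.4-fold higher number from compound 1 to compound 4 (0.38 log units; beyond the scatter), the first step in the series to leave the scatter, and it remains a modest one. No measurement is at hand that explains either step.

Compound 2 carries no number, so steps to or from it cannot be read. Going by these compounds, whether an amine or a carboxylic acid on the phenyl ring at this place would move the number beyond the scatter remains open, as does the effect of bromo in place of chloro or fluoro.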